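Rearranging the aryl headgroup of a urea inhibitor

A few compounds are considered here, and "the series" means these few. Any claim that something is new, unique, unknown or untested is made for them only; others in the source may bear on it.

Compound 2 `O=C(Nc1ccn2ccnc2c1)N1CCN(Cc2cccc(Oc3ccc(Cl)cc3)c2)CC1` holds the highest of the two numbers recorded so far in an assay on isolated protein for inhibition of Fatty-acid amide hydrolase 1 (Homo sapiens), with a stated time of 60 min; a lower number here means a stronger inhibitor, a higher number a weaker inhibitor; in this assay compound 2 gives 33 nM. Going by the values given here, its only neighbour is compound 1 `O=C(Nc1cccc2nonc12)N1CCN(Cc2cccc(Oc3ccc(Cl)cc3)c2)CC1`, which in this assay gives 28 nM, and the step of a 1.2-fold higher number from compound 1 to compound 2 (0.07 log units; within the scatter) falls within the scatter. Compound 3 `O=C(Nc1ccc2nccn2c1)N1CCN(Cc2cccc(Oc3ccc(Cl)cc3)c2)CC1` has not yet been measured. It differs from compound 2 by a group of 9 heavy atoms (7 carbon, 2 nitrogen; one five-membered aromatic ring with 2 hetero atoms, one six-membered aromatic ring with 1 hetero atom) in place of a group of 9 heavy atoms (7 carbon, 2 nitrogen; one five-membered aromatic ring with 2 hetero atoms, one six-membered aromatic ring with 1 hetero atom), on an amide-type nitrogen; the two structures contain the same atoms, joined differently. Among the compounds with values here, the single measured step at this position, a 1.2-fold higher number from compound 1 to compound 2 (0.07 log units; within the scatter), shows that exchanging one bicyclic aromatic group for another on the amide-type nitrogen left the number essentially unchanged. The same is therefore expected here: no step beyond the scatter, with the change a 1.0-fold lower number from compound 2 to compound 3 (0.01 log units; within the scatter) expected. Compound 3 is accordingly estimated at 32 nM in this assay, within a range of 12 nM to 85 nM.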

Compound 3, half-maximal inhibitory concentration: 100 nM
Compound 3: the middle estimate sits 3.1-fold (0.49 log units) below what was measured; the whole stated range lies below it.
By their numbers in this assay, from the lowest: compounds 1 and 2 (each within the scatter of the next); then compound 3.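

In this assay, the group on the amide-type nitrogen proves sensitive to how its atoms are joined, not only to which atoms it holds. The step of a 3.0-fold higher number from compound 2 to compound 3 (0.48 log units; beyond the scatter) is beyond the scatter. The two groups have the same atom counts, ring types, hydrogen-bond donors and acceptors and net charge. Compound 1 and compound 2, whose groups differ in composition, showed no such separation, whereas a 3.6-fold higher number from compound 1 to compound 3 (0.55 log units; beyond the scatter) sets compound 3 apart from compound 1 as well, so these three bicyclic groups are not interchangeable at this place. Nothing measured here accounts for the difference.

On these data alone, it remains open how far this sensitivity extends to other groups at this place. It is also unknown whether a methyl or a carboxylic acid added to the group on the amide-type nitrogen would change the number in compound 3.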